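Bromoacetyl series: dichlorophenyl replaces furanyl on the saturated carbon

The source may hold more compounds than are shown below. What is called first, only, known or untested is meant among the compounds shown, and "the series" means these compounds.

Of the compounds shown here, two of the shared core carry numbers so far. Compound 1 `COc1ccc(C2=NNC(c3c(Cl)cccc3Cl)C2)cc1OC` gives 49% in a functional assay on the whole organism (strain albino) for inhibition, with Rattus norvegicus as the target, read by paw edema, with stated times of 30 min and 2 h, at a dose of 100 mg/kg by the oral route; a lower number here means less inhibition, a higher number more inhibition at the dose given (going by the name of the read-out). Compound 2 `COc1ccc(C2=NN(C(=O)CBr)C(c3ccco3)C2)cc1OC` gives 46% in this assay; compound 2 stands within the scatter of compound 1, and the two values show no separation that can be read as a difference. Going by the values given here, no step between them is counted, as they differ in more than one place.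

Compound 3 `COc1ccc(C2=NN(C(=O)CBr)C(c3c(Cl)cccc3Cl)C2)cc1OC` is not yet measured. It differs from compound 2 in one place: 2,6-dichlorophenyl in place of furan-2-yl on a saturated ring carbon. The same 2,6-dichlorophenyl is present in compound 1, whose value of 49% sits beside that of compound 2. On that basis the step from compound 2 to compound 3 is expected to be small, a number 4 percentage points higher from compound 2 to compound 3 (within the scatter), none beyond the scatter in either direction. Compound 3 is therefore estimated at 50%, with a range of 35% to 65%.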

Compound 3, a percentage reported as inhibition, in the whole organism at one dose (the size of the read-out at that dose, not a potency): 58%
Beside the measured number, compound 3's estimate is 8 percentage points below it; the measured number falls inside the stated range.
By their numbers in this assay, from the lowest: compounds 2, 1 and 3 (each within the scatter of the next, the first and the last beyond it).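

Going by these compounds alone, on the saturated ring carbon, 2,6-dichlorophenyl in place of furan-2-yl gives a number 12 percentage points higher from compound 2 to compound 3 (beyond the scatter) in this assay, the first step at this position that can be read and one that clears the usual spread of repeat measurements. With 2,6-dichlorophenyl held constant, (bromomethyl)carbonyl in place of hydrogen on the amine nitrogen in the ring gives a number 9 percentage points higher from compound 1 to compound 3 (within the scatter) and so does not separate the acylated compound from the free amine at this dose. No measurement shown gives a reason for either step.

Still open, on these data alone, is whether the step at the ring carbon belongs to the chlorines or to the benzene ring itself, which unsubstituted phenyl would separate. Also open, as far as these compounds go, is how the series responds when an amine such as a dimethylamino group replaces the bromine on the acyl chain.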